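Adding Chloro Within a Series Held at the Assay Limit

The source may report more compounds than this note shows. Statements on the series, on what has been measured and on what is new or still open speak of the compounds shown alone.

Three compounds were tested in a functional assay on HepG2 cells (Homo sapiens) for cytotoxicity, read by MTT assay, with a stated time of 48 h; a lower number here means a stronger inhibitor, a higher number a weaker inhibitor. Compound 2 has the structure `Cc1nnc(SCC(=O)c2ccccc2)n1N1C(=O)c2ccccc2C1=O`. In this assay compound 2 gives > 200000 nM, which is a limit of the assay and not a number. Compound 1, `Cc1nnc(SCC(=O)c2ccc(Cl)cc2)n1N1C(=O)c2ccccc2C1=O`, differs from compound 2 by chloro in place of hydrogen on an aromatic carbon. In this assay compound 1 gives > 200000 nM, again a limit. The step is a step that the two limits leave unreadable from compound 2 to compound 1. Compound 3, `CCc1nnc(SCC(=O)c2ccccc2)n1N1C(=O)c2ccccc2C1=O`, differs from compound 2 by methyl in place of hydrogen on a saturated chain carbon bound to an aromatic carbon; this is how the two cores differ. In this assay compound 3 gives > 200000 nM, also a limit. The step is a step that the two limits leave unreadable from compound 2 to compound 3. All three values sit at the limit of > 200000 nM in this assay, at which 3 of the 3 values shown sit, so none of the steps among them can be read.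

Compound 4, `CCc1nnc(SCC(=O)c2ccc(Cl)cc2)n1N1C(=O)c2ccccc2C1=O`, has not yet been measured. For the measured compounds named here, it differs from compound 3 by chloro in place of hydrogen on an aromatic carbon, and this is the same change as the one from compound 2 to compound 1, whose step was a step that the two limits leave unreadable from compound 2 to compound 1, here made on the core of compound 3 instead. Because compound 3 sits at > 200000 nM and the earlier step could not be read, the step from compound 3 to compound 4 is expected to be a step that the limit leaves unreadable from compound 3 to compound 4. Compound 4 is therefore expected to give about 300000 nM. The expected range for compound 4 runs from 150000 nM to 1000000 nM, and the reading is more likely to come back as a limit than as a number.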

Compound 4, half-maximal inhibitory concentration: > 200000 nM
Compound 4 ended at the assay's limit; the forecaster's own chance of this, stated with the estimate: 85%; the middle value is on the limit's open side.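

In this assay compound 4 gives > 200000 nM, a limit of the assay and not a number. The steps to compound 4 from compound 3 and from compound 1 cannot be read, because all the values sit at one limit: the limit of > 200000 nM in this assay, at which 4 of the 4 values shown sit. The compounds shown leave open whether either chloro in place of hydrogen or methyl in place of hydrogen changes the read-out at all.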